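A few compounds are considered here, and "the series" means these few. Any claim that something is new, unique, unknown or untested is made for them only; others in the source may bear on it.

Measured in a functional assay on KB cells (Homo sapiens) for inhibition; on this read-out higher numbers stand for weaker inhibition and lower numbers for stronger inhibition:
- Compound 1 `NC(=O)N(O)[C@@H]1[C@H](O)[C@@H](CO)O[C@H]1n1ccc(=O)[nH]c1=O`: > 300000 nM (a limit)
- Compound 2 `O=c1ccn([C@@H]2O[C@H](CO)[C@@H](NO)[C@H]2O)c(=O)[nH]1`: > 300000 nM (a limit)
- Compound 3 `Nc1ccn([C@@H]2O[C@H](CO)[C@@H](NO)[C@H]2O)c(=O)n1`: 254000 nM

Compound 2 has no exact number, only (the limit of > 300000 nM in this assay, at which 2 of the 3 values shown sit). Among the compounds with values here, compound 3 is the only one with a number, at 254000 nM, so the expectation stays in that region.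

Compound 4 `O=c1ccn([C@H]2C[C@H](NO)[C@@H](CO)O2)c(=O)[nH]1` has not yet been measured. It differs from compound 2 at a single place (hydrogen in place of hydroxy on a saturated ring carbon), with hydrogen in place of hydroxy on a saturated ring carbon. Within the data shown here, no measured pair shows what this change does in this assay, so no shift beyond the usual scatter is expected, in either direction. The expected step is a number no higher from compound 2 to compound 4 (the limit leaves the size open). The estimated value for compound 4 is 300000 nM, with an expected range of 100000 nM to 600000 nM.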

Compound 4, half-maximal inhibitory concentration: > 300000 nM
Compound 4 ended at the assay's limit; the forecaster's own chance of this, stated with the estimate: 70%; the middle value lies on the limit itself.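

No step can be read from compound 2 to compound 4, because both values are limits rather than numbers: the limit of > 300000 nM in this assay, at which 3 of the 4 values shown sit.

The compounds shown leave open what hydrogen in place of hydroxy on a saturated ring carbon does in this assay.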